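The compounds below may be only part of what the source reports. "The series", "measured", "known", "first", "only" and "open" are said of these compounds alone.

Measured so far in an ADME assay on cells (Homo sapiens) for cytotoxicity, read by polymerase chain reaction, with a stated time of 3 days; on this read-out higher numbers stand for lower toxicity in this test and lower numbers for higher toxicity in this test
compound 1 `Cc1nc(NCc2ccsc2)nc(N[C@@H]2C[C@H](CO)[C@@H](O)[C@H]2O)c1-c1nc2ccccc2s1` gives 6000 nM
compound 2 `Cc1nc(NCc2ccccn2)nc(N[C@@H]2C[C@H](CO)[C@@H](O)[C@H]2O)c1-c1nc2ccccc2s1` gives 13000 nM

Compound 2 holds the higher of the two numbers, 13000 nM, and so reads as the less toxic of the pair. Next in line is compound 3 `Cc1nc(NCc2cccnc2)nc(N[C@@H]2C[C@H](CO)[C@@H](O)[C@H]2O)c1-c1nc2ccccc2s1`, which has the same atoms joined differently: pyridin-3-yl in place of pyridin-2-yl on a saturated chain carbon bound to a nitrogen on an aromatic ring. In short, pyridin-3-yl stands in place of pyridin-2-yl.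

Among the compounds with values here, only one measured step concerns this place: a 2.2-fold higher number from compound 1 to compound 2 (0.34 log units; beyond the scatter). It is modest, and it exchanged thiophen-3-yl for pyridin-2-yl. Within the data shown here, no measured pair compares the two pyridinyl groups directly, so the direction is poorly supported. A change no larger than that modest step is expected in this assay.

The estimate is a 1.3-fold lower number from compound 2 to compound 3 (0.11 log units; within the scatter), which is expected to stay within the scatter. For compound 3 the expected value is 10000 nM, with an estimated range from 5000 nM to 20000 nM.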

Compound 3, half-maximal cytotoxic concentration: 5000 nM
Beside the measured number, compound 3's estimate is 2.0-fold (0.30 log units) above it; low and high end bracket the measured number.
By their numbers in this assay, from the lowest: compounds 3 and 1 (each within the scatter of the next); then compound 2.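

In this assay, the swap of pyridin-3-yl for pyridin-2-yl on a saturated chain carbon bound to a nitrogen on an aromatic ring gives a 2.6-fold lower number from compound 2 to compound 3 (0.41 log units; beyond the scatter) and shows that this place responds to how the pyridine ring is joined, not only to its presence. The comparison with thiophen-3-yl gives a 1.2-fold lower number from compound 1 to compound 3 (0.08 log units; within the scatter) and so does not separate these two groups, which leaves compound 2 alone with the higher number; compound 3 goes against any reading that pyridinyl groups as a class give higher numbers here. Nothing available accounts for the gap separating the two pyridinyl groups.

The compounds shown leave open whether pyridin-4-yl or phenyl at this place would stay with compound 2 or with compound 1 and compound 3. They also leave open whether the same gap persists with (pyridinyl)ethyl in place of (pyridinyl)methyl.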